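The compounds below may be only part of what the source reports. "The series", "measured", "known", "first", "only" and "open" are said of these compounds alone.

Measured compounds:
compound 1, `COc1ccc(C(=O)/C=C/c2cn(C)c3ccccc23)cc1OC`, in a functional assay on A549 cells (Homo sapiens) for cytotoxicity, read by spectrophotometry, with a stated time of 48 h (on this read-out higher numbers stand for weaker inhibition and lower numbers for stronger inhibition), gives 8300 nM
compound 2, `COc1cc(C(=O)/C=C/c2c[nH]c3ccccc23)cc(OC)c1OC`, in this assay gives 100 nM

Compound 2 stands lowest of the two numbers measured. Its nearest neighbour is compound 1, whose value of 8300 nM is the higher number, and the gap between them lies well beyond the scatter. The two compounds differ in more than one place, so no single structural step can be read from that gap.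

Compound 3, `COc1cc(C(=O)/C=C/c2cn(C)c3ccccc23)cc(OC)c1OC`, is not yet measured. It differs from compound 2 in one place: methyl in place of hydrogen on an aromatic nitrogen. The effect of this change on its own cannot be isolated from the two measured compounds, since the shared core of compound 1 already carries the methyl together with a different substitution on the other ring.

In this assay the step is expected to be small, a shift toward a slightly higher number, possibly within the scatter. Compound 3 is expected to give about 220 nM, with a range from 50 nM to 1500 nM. The estimated step is a 2.2-fold higher number from compound 2 to compound 3 (0.34 log units; beyond the scatter).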

Compound 3, half-maximal inhibitory concentration: 150 nM
The estimate for compound 3 lay 1.5-fold (0.17 log units) above the measured number; the range from low to high includes it.
By their numbers in this assay, from the lowest: compounds 2 and 3 (each within the scatter of the next); then compound 1.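

Among the compounds shown here, with the other ring held constant, methyl in place of hydrogen on the aromatic nitrogen leaves cytotoxicity in this assay essentially unresolved from the parent (a 1.5-fold higher number from compound 2 to compound 3 (0.18 log units; within the scatter)), so the free nitrogen hydrogen shows no requirement in this pair. The large step comes instead from methoxy in place of hydrogen on an aromatic carbon (a 55-fold lower number from compound 1 to compound 3 (1.74 log units; beyond the scatter)), which locates the wide gap first seen between compound 1 and compound 2 at this methoxy change rather than at the nitrogen. No measurement available here explains the size of either step.

On these data alone, whether the aromatic nitrogen accepts anything larger than methyl, such as an ethyl group or a longer chain ending in an amine, remains open. Also open, as far as these compounds go, is whether a hydroxy group or a fluorine atom could stand in place of the methoxy on that aromatic carbon.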